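The source may report more compounds than this note shows. Statements on the series, on what has been measured and on what is new or still open speak of the compounds shown alone.

Compound 1 `CCCCCCCC/C=C/CCCCCCCC(=O)O[C@H]1[C@H](O)[C@H](n2ccc(N)nc2=O)O[C@@H]1CO`: 0.05 ug/mL
Compound 2 `CCCCCCCC(=O)O[C@H]1[C@H](O)[C@H](n2ccc(N)nc2=O)O[C@@H]1CO`: 0.1 ug/mL
Compound 3 `CCCCCCC/C=C\C(=O)O[C@H]1[C@H](O)[C@H](n2ccc(N)nc2=O)O[C@@H]1CO`: 0.06 ug/mL

All three share one core and differ only in the ester chain. In a functional assay on HeLa cells (Homo sapiens) for cytotoxicity, read by cell counting, with a stated time of 48 h (a lower number here means that less compound is needed, a higher number that more compound is needed for the effect), compound 2 gives the largest of the three numbers, yet its gaps to compound 3 and to compound 1 both lie within the scatter. The unmeasured compound 4 `CCCCCCCCCCCCCCCC(=O)O[C@H]1[C@H](O)[C@H](n2ccc(N)nc2=O)O[C@@H]1CO` differs from compound 2 in one place: octyl in place of hydrogen on a saturated chain carbon, seven bonds along the chain from a carbonyl carbon. For the measured compounds named here, two measured steps bear on this change. The step of a 2.0-fold higher number from compound 1 to compound 2 (0.30 log units; within the scatter) and the step of a 1.7-fold lower number from compound 2 to compound 3 (0.22 log units; within the scatter) each moved the number only a little, and both stayed within the scatter. For compound 4 a lengthened chain is therefore expected to give at most a small drop in number: a 1.7-fold lower number from compound 2 to compound 4 (0.22 log units; within the scatter). Compound 4 is estimated at 0.06 ug/mL, with a range from 0.03 ug/mL to 0.13 ug/mL.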

Compound 4, concentration for half-maximal effect: 0.24 ug/mL
Compound 4: the middle estimate sits 4.0-fold (0.60 log units) below what was measured; measured number outside the range, above it.
By their numbers in this assay, from the lowest: compounds 1, 3 and 2 (each within the scatter of the next); then compound 4.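

Octyl in place of hydrogen at this position gives a 2.4-fold higher number from compound 2 to compound 4 (0.38 log units; beyond the scatter) in this assay, the first step here to go beyond the scatter, so adding chain at this carbon does not always leave the number unchanged. The size of the added group alone does not set the number either: octyl in place of a larger group at this carbon gives a 4.8-fold higher number from compound 1 to compound 4 (0.68 log units; beyond the scatter). Nothing available explains this rise. Still open, going by these compounds, is how a butyl group, or a chain ending in an amine or a carboxylic acid, would behave at this position.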